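The compounds below may be only part of what the source reports. "The series", "measured", "known", "first", "only" and "open" are said of these compounds alone.

Measured compounds:
compound 1 `O=C(O)/C=C/C(=O)c1ccc(F)cc1`: 33800 nM
compound 2 `Cc1ccc(C(=O)/C=C/C(=O)O)cc1C`: 12100 nM

In a functional assay on LS174T cells (Homo sapiens) for inhibition, read by MTT assay, with a stated time of 72 h (on this read-out lower numbers stand for stronger inhibition and higher numbers for weaker inhibition), compound 1 gives 33800 nM, the highest of the two numbers; compound 2 gives 12100 nM, a lower number beyond the usual scatter. The unmeasured compound 3 `CC(C)c1ccc(C(=O)/C=C/C(=O)O)cc1` differs from compound 1 by isopropyl in place of fluoro on an aromatic carbon. For the measured compounds named here, no step between measured compounds covers this change, so the expectation rests only on the two values. The lower number of compound 2 at 12100 nM points toward stronger inhibition for the change. A modest step of a 2.8-fold lower number from compound 1 to compound 3 (0.45 log units; beyond the scatter) is therefore expected. Compound 3 is estimated at 12000 nM, within 4000 nM to 36000 nM.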

Compound 3, half-maximal inhibitory concentration: 25700 nM
Compound 3: the middle estimate sits 2.1-fold (0.33 log units) below what was measured; the measured number falls inside the stated range.
By their numbers in this assay, from the lowest: compound 2; then compounds 3 and 1 (each within the scatter of the next).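

In this assay, isopropyl in place of fluoro on this aromatic carbon gives a 1.3-fold lower number from compound 1 to compound 3 (0.12 log units; within the scatter) on the shared core, the first single-place step available. At this position, then, the read-out does not separate the fluoro group of 1 heavy atom from the isopropyl group of 3 heavy atoms. No measurement shown bears on this result, so nothing can be said of what lies behind it. Still open, from the compounds shown here alone, is whether an amine or a methoxy group on the same aromatic carbon would also stay within the scatter of compound 1.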